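From an acetyl to a benzoyl on the ring nitrogen

The source may report more compounds than this note shows. Statements on the series, on what has been measured and on what is new or still open speak of the compounds shown alone.

The study measures growth inhibition in a functional assay on ACHN cells (Homo sapiens) for cytotoxicity, read by sulforhodamine B assay, with a stated time of 72 h; on this read-out lower numbers stand for stronger inhibition of growth and higher numbers for weaker inhibition of growth. Compound 1 `O=C(Nc1ccccc1C(F)(F)F)C1CCc2ccccc2N1C(=O)c1cccc(Cl)c1` gives 526 nM in this assay. Compound 2 `COc1ccc(NC(=O)C2CCc3ccccc3N2)cc1`, which carries no acyl group on the ring nitrogen, gives 38000 nM. For the measured compounds named here, compound 3 `CC(=O)N1c2ccccc2CCC1C(=O)Nc1cc(C(F)(F)F)cc(C(F)(F)F)c1` gives only a limit, > 70000 nM, and so its inhibition is known just to lie beyond what this assay reports; it is the one value at the limit of > 70000 nM in this assay, at which 1 of the 3 values shown sits. Among the three compounds, compound 3 therefore stands at the weak end of the measured numbers, with compound 1 the only one reaching the sub-micromolar range.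

Compound 4 `O=C(Nc1cc(C(F)(F)F)cc(C(F)(F)F)c1)C1CCc2ccccc2N1C(=O)c1ccccc1` has not been measured. It differs from compound 3 by phenyl in place of methyl on a carbonyl carbon. Going by the values given here, no step between measured compounds isolates this change, so the size of the effect is open. Among the compounds with values here, compound 1, the one compound carrying a benzoyl-type group on the ring nitrogen, gives 526 nM, which points toward stronger inhibition for compound 4 than is seen for compound 3. Compound 4 is therefore expected to gain clearly, with an estimated step of an at least 17-fold lower number from compound 3 to compound 4 (1.24 log units; beyond the scatter) in this assay. Compound 4 is estimated at 4000 nM, within a range from 600 nM to 30000 nM.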

Compound 4, concentration for 50% growth inhibition: 2920 nM
Compound 4: the middle estimate sits 1.4-fold (0.14 log units) above what was measured, within the range that was stated.
By their numbers in this assay, from the lowest: compound 1; then compound 4; then compound 2. At a limit, above all of these: compound 3.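

Replacing acetyl with benzoyl on the carbonyl carbon attached to the ring nitrogen, with the rest of the structure held fixed, gives an at least 23-fold lower number from compound 3 to compound 4 (1.37 log units; beyond the scatter) in this assay, which shows that this one place alone can move growth inhibition by a large step. The value of compound 3 is a limit of the assay, and the step therefore gives only a lower bound on the size of the change: the limit of > 70000 nM in this assay, at which 1 of the 4 values shown sits.

For the compounds shown here, the earlier compounds offered no pair differing in this one place, and this pair is the first to isolate the change from the rest of the structure.

The compounds shown do not tell whether an aromatic ring is needed on this carbonyl, which a cyclohexyl group or a longer chain in place of phenyl would address, or whether an amine or a carboxylic acid on the phenyl ring would move the number further. As far as these compounds go, it also stays open whether the same step holds with other groups on the amide nitrogen of the shared core, and compound 1 and compound 4 differ in more than one place, so they do not settle this.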